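A few compounds are considered here, and "the series" means these few. Any claim that something is new, unique, unknown or untested is made for them only; others in the source may bear on it.

Measured so far in a functional assay on the whole organism with Mus musculus as the target, in the hot plate test; on this read-out lower numbers stand for an effect already at smaller amounts and higher numbers for an effect only at larger amounts of compound:
compound 1 `COc1ccccc1C(=O)OC1CCN(C)CC1` — 10.6 mg/kg
compound 2 `COc1cccc(C(=O)OC2CCN(C)CC2)c1OC` — 8.9 mg/kg

Compound 1 holds the highest of the two numbers in this assay; the nearest is compound 2, at a 1.2-fold lower number from compound 1 to compound 2 (0.08 log units; within the scatter). Compound 3 `CN1CCC(OC(=O)c2ccccc2F)CC1` differs from compound 1 by fluoro in place of methoxy on an aromatic carbon. Among the measured compounds shown here, no measured step exchanges methoxy for fluoro. For the measured compounds named here, the only step known, a 1.2-fold lower number from compound 1 to compound 2 (0.08 log units; within the scatter), adds a methoxy and stays within the scatter, so it offers little guidance for the change in hand. For compound 3 the expected step is a 1.0-fold higher number from compound 1 to compound 3 (0.02 log units; within the scatter), none beyond the scatter. Compound 3 is therefore estimated at 11 mg/kg, with a range from 5 mg/kg to 25 mg/kg.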

Compound 3, dose for half-maximal effect: 10.6 mg/kg
Estimate against measurement, compound 3: 1.0-fold (0.02 log units) above; the range from low to high includes it.
By their numbers in this assay, from the lowest: compounds 2, 1 and 3 (each within the scatter of the next).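

Fluoro in place of methoxy on this aromatic carbon, ortho to a large group, gives no change at the digits printed from compound 1 to compound 3 (within the scatter) in this assay. The earlier step only added a methoxy, whereas here the methoxy itself leaves, so the read-out does not depend on that group being present, at least when fluoro enters, with one heavy atom and no hydrogen-bond acceptor by the count. No measurement at hand bears on why the two groups read alike. As far as these compounds go, whether an amine or a carboxylic acid on this carbon would also hold the read-out stays open. So does whether the same exchange behaves alike on the core of compound 2.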